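The source may hold more compounds than are shown below. What is called first, only, known or untested is meant among the compounds shown, and "the series" means these compounds.

Compound 1, `CCCCCCNS(=O)(=O)NC(=O)Oc1c(C(C)(C)C)cc(C)cc1C(C)(C)C`, gives 19400 nM in an assay on liver for inhibition of sterol O-acyltransferase 1 (Rattus norvegicus), using microsomes; a higher number here means a weaker inhibitor, a lower number a stronger inhibitor; compound 2, `CCCCCN(CCCCC)S(=O)(=O)NC(=O)Oc1c(C(C)(C)C)cc(C)cc1C(C)(C)C`, gives 2200 nM.

Compound 2 stands lowest of the two numbers, with compound 1 the nearest, an 8.8-fold lower number from compound 1 to compound 2 (0.95 log units; beyond the scatter). Compound 3, `Cc1cc(C(C)(C)C)c(OC(=O)NS(=O)(=O)Oc2ccccc2)c(C(C)(C)C)c1`, has not yet been measured; it differs from compound 2 in one place: phenoxy in place of dipentylamino on a sulfonyl sulfur. Going by the values given here, only the step from compound 1 to compound 2 touches this sulfonyl sulfur, and it was modest. Among the compounds with values here, the phenoxy group has no counterpart in the measured pair, so the direction is uncertain; a step back toward compound 1 seems more likely than a further fall. Compound 3 is expected to give about 6000 nM, between 1500 nM and 25000 nM, a step of a 2.7-fold higher number from compound 2 to compound 3 (0.44 log units; beyond the scatter).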

Compound 3, half-maximal inhibitory concentration: 90000 nM
For compound 3 the middle estimate is 15-fold (1.18 log units) below the measured one; the whole stated range lies below it.
By their numbers in this assay, from the lowest: compound 2; then compound 1; then compound 3.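

In this assay, phenoxy on this sulfonyl sulfur gives the weakest inhibitor of the three, with a 41-fold higher number from compound 2 to compound 3 (1.61 log units; beyond the scatter) and a 4.6-fold higher number from compound 1 to compound 3 (0.67 log units; beyond the scatter). The position therefore responds in both directions, and the result shows that a group with a ring bound through oxygen falls behind both the hexylamino and the dipentylamino groups. Nothing available accounts for this drop. The compounds shown leave open whether an anilino group, with the same ring on nitrogen, would follow phenoxy or the amino groups. As far as these compounds go, how a dialkylamino group with longer chains would compare also remains open.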